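The source may report more compounds than this note shows. Statements on the series, on what has been measured and on what is new or still open speak of the compounds shown alone.

Compound 1 `Cc1cn([C@@H]2C[C@H](O)[C@@H](CNC(=O)Nc3ccc(Cl)cc3)O2)c(=O)[nH]c1=O` and compound 2 `Cc1cn([C@@H]2C[C@H](O)[C@@H](CNC(=O)Nc3ccc(Br)cc3)O2)c(=O)[nH]c1=O` share one core and differ by bromo in place of chloro on an aromatic carbon. In an ADME assay on MRC5 cells (Homo sapiens) for cytotoxicity (on this read-out lower numbers stand for higher toxicity in this test and higher numbers for lower toxicity in this test), compound 1 gives > 50000 nM, a limit of the assay. In this assay compound 2 gives > 50000 nM, likewise a limit. Going by the values given here, the step that the two limits leave unreadable from compound 1 to compound 2 is therefore not readable; the only evidence is the limit of > 50000 nM in this assay, at which 2 of the 2 values shown sit. Compound 3 `COc1ccc(NC(=O)NC[C@H]2O[C@H](n3cc(C)c(=O)[nH]c3=O)C[C@@H]2O)cc1` differs from compound 2 by methoxy in place of bromo on an aromatic carbon. Among the compounds with values here, no measured step covers this change. The expected step is a step that the limit leaves unreadable from compound 2 to compound 3. Compound 3 is estimated at 60000 nM, with a range from 25000 nM to 150000 nM, most likely again reported only as a limit.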

Compound 3, half-maximal cytotoxic concentration: > 50000 nM
Compound 3: no number, only a limit (the forecaster's own chance of this, stated with the estimate: 85%); the middle value does not contradict the limit.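

No step among compound 1, compound 2 and compound 3 can be read, since all three values in this assay are limits: the limit of > 50000 nM in this assay, at which 3 of the 3 values shown sit.

The compounds shown leave open whether the chloro, bromo and methoxy groups differ at all in this assay.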